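Swapping the Aromatic Group of Compound 2

A few compounds are considered here, and "the series" means these few. Any claim that something is new, unique, unknown or untested is made for them only; others in the source may bear on it.

In a functional assay on B16-F10 cells (Mus musculus) for antiproliferative activity, read by MTT assay, with a stated time of 48 h (on this read-out higher numbers stand for weaker inhibition and lower numbers for stronger inhibition), compound 1 `O=C(/C=C/c1ccc(O)c(O)c1)N1CCN(c2cccc(Cl)c2)CC1` gives 1.71 ug/mL, compound 2 `COc1ccccc1N1CCN(C(=O)/C=C/c2ccc(O)c(O)c2)CC1` gives 1.23 ug/mL and compound 3 `O=C(/C=C/c1ccc(O)c(O)c1)N1CCN(c2cccc(C(F)(F)F)c2)CC1` gives 2.01 ug/mL. Compound 2 therefore stands among close neighbours, with no gap beyond the scatter separating it from either of the others.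

Compound 4 `Cc1ccc(N2CCN(C(=O)/C=C/c3ccc(O)c(O)c3)CC2)c(C)c1` has not yet been measured. It keeps the shared core of compound 2 and carries 2,4-dimethylphenyl in place of 2-methoxyphenyl on an amine nitrogen in a ring.

Among the measured compounds shown here, two measured steps bear on this swap, since both alter the same aromatic group. One is a 1.4-fold lower number from compound 1 to compound 2 (0.14 log units; within the scatter), and the other is a 1.2-fold higher number from compound 1 to compound 3 (0.07 log units; within the scatter). Both are small and lie within the scatter. For the measured compounds named here, no measured compound yet carries 2,4-dimethylphenyl, so this comparison is only a guide. In this assay, no step beyond the scatter is expected. The expected change is a 1.4-fold higher number from compound 2 to compound 4 (0.14 log units; within the scatter). Compound 4 is estimated at 1.7 ug/mL, with an expected range from 0.9 ug/mL to 3.2 ug/mL.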

Compound 4, half-maximal inhibitory concentration: 1.43 ug/mL
The estimate for compound 4 lay 1.2-fold (0.08 log units) above the measured number; the range from low to high includes it.
By their numbers in this assay, from the lowest: compounds 2, 4, 1 and 3 (each within the scatter of the next).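

In this assay, the change to 2,4-dimethylphenyl gives a 1.2-fold higher number from compound 2 to compound 4 (0.07 log units; within the scatter), so an aromatic group of carbon only, with no hydrogen-bond acceptor, is accommodated here without a step beyond the scatter. Set against 3-chlorophenyl, the same group gives a 1.2-fold lower number from compound 1 to compound 4 (0.08 log units; within the scatter), which shows that two methyl groups on the aromatic ring also leave the number within the scatter. Nothing available explains why these changes have so little effect on the number.

All the groups shown at this position are substituted phenyl rings. Going by these compounds, whether a phenyl ring bearing a carboxylic acid or an amine, or a plain alkyl chain in place of the ring, would produce a step beyond the scatter remains open.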